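A few compounds are considered here, and "the series" means these few. Any claim that something is new, unique, unknown or untested is made for them only; others in the source may bear on it.

In a physicochemical assay for solubility, with a stated time of 24 h, tested at 30 mg/mL (on this read-out higher numbers stand for higher solubility and lower numbers for lower solubility), compound 1 (`Cc1cc(COc2ccc(S(=O)(=O)N(C)C3(C(=O)NO)CN(C(=O)C(C)C)C3)cc2)c2ccccc2n1`) gives 56000000 nM. Compound 2 (`CCN(C1(C(=O)NO)CN(C(=O)C(C)C)C1)S(=O)(=O)c1ccc(OCc2cc(C)nc3ccccc23)cc1`) gives 44000000 nM, and these two numbers lie within the scatter of each other. Compound 3 (`COCCN(C1(C(=O)NO)CN(C(=O)C(C)C)C1)S(=O)(=O)c1ccc(OCc2cc(C)nc3ccccc23)cc1`) has methoxy in place of hydrogen on a saturated chain carbon, two bonds along the chain from a sulfonamide nitrogen, so that ethyl becomes 2-methoxyethyl: methoxy in place of hydrogen on a saturated chain carbon, two bonds along the chain from a sulfonamide nitrogen. Within the data shown here, only one measured step bears on this chain, methyl in place of hydrogen on a saturated chain carbon bound to a sulfonamide nitrogen. It gave a 1.3-fold lower number from compound 1 to compound 2 (0.10 log units; within the scatter). Among the measured compounds shown here, no measured compound carries the methoxy group, so the evidence is thin. With that single step as the guide, no change beyond the scatter is expected in this assay. The expected step is a 1.1-fold lower number from compound 2 to compound 3 (0.04 log units; within the scatter). For compound 3 the estimated value is 40000000 nM, with an expected range of 18000000 nM to 55000000 nM.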

Compound 3, solubility: 8900000 nM
Compound 3: the middle estimate sits 4.5-fold (0.65 log units) above what was measured, and the stated range ends above it.
By their numbers in this assay, from the lowest: compound 3; then compounds 2 and 1 (each within the scatter of the next).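

Methoxy in place of hydrogen on a saturated chain carbon, two bonds along the chain from a sulfonamide nitrogen, gives a 4.9-fold lower number from compound 2 to compound 3 (0.69 log units; beyond the scatter) in this assay, whereas the earlier methyl step stayed within the scatter. Taken from the shorter chain, methoxymethyl in place of hydrogen on a saturated chain carbon bound to a sulfonamide nitrogen gives a 6.3-fold lower number from compound 1 to compound 3 (0.80 log units; beyond the scatter), so substitution on this chain can move this read-out, and compound 3 stands lowest of the three. No measurement among these compounds accounts for the drop.

Still open, on these data alone, is whether the lower number follows the ether oxygen or the chain length, a question that a propyl or butyl chain on the sulfonamide nitrogen would address. A terminal hydroxyl, amine or carboxylic acid on the ethyl chain also remains to be read in this assay.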